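The compounds below may be only part of what the source reports. "The series", "measured", "known", "first", "only" and "open" are said of these compounds alone.

Measured in a physicochemical assay for solubility, read by HPLC, using the shake flask method, in phosphate buffer, with a stated time of 2 h, at pH 6.5; on this read-out lower numbers stand for lower solubility and higher numbers for higher solubility:
- compound 1 `NC(=O)c1ccc(-c2cnc(N)c(-c3ccc(C(F)(F)F)cc3)n2)cc1`: < 5000 nM (a limit)
- compound 2 `Nc1ncc(-c2ccc(C(=O)N3CC[C@@H](O)C3)cc2)nc1-c1ccc(C(F)(F)F)cc1`: 90000 nM
- compound 3 `Nc1ncc(-c2ccc(C(=O)O)cc2)nc1-c1ccc(C(F)(F)F)cc1`: 95000 nM

Compound 1 has only a limit, < 5000 nM, not a number. Compound 4 `CNC(=O)c1ccc(-c2nc(-c3ccc(C(N)=O)cc3)cnc2N)cc1` differs from it by methylcarbamoyl in place of trifluoromethyl on an aromatic carbon, para to a large group. Among the measured compounds shown here, no measured step touches this place. The measured steps all change the group on the carbonyl carbon: an at least 18-fold higher number from compound 1 to compound 2 (1.25 log units; beyond the scatter) and an at least 19-fold higher number from compound 1 to compound 3 (1.27 log units; beyond the scatter) are large, while a 1.1-fold higher number from compound 2 to compound 3 (0.02 log units; within the scatter) lies within the scatter. Compound 4 keeps the amino on that carbonyl carbon, so these steps bear only indirectly, and a smaller upward move is expected, with a further limit reading possible. The expected step is an at least 3.0-fold higher number from compound 1 to compound 4 (0.47 log units; beyond the scatter). Compound 4 is estimated at 15000 nM, with an expected range of 5000 nM to 80000 nM.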

Compound 4, solubility: 178000 nM
Estimate against measurement, compound 4: 12-fold (1.07 log units) below; the measured number lies above the stated range.
By their numbers in this assay, from the lowest: compounds 2, 3 and 4 (each within the scatter of the next). At a limit, below all of these: compound 1.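

In this assay, the place on the aromatic carbon, para to a large group, now has a step of its own, with methylcarbamoyl in place of trifluoromethyl giving an at least 35-fold higher number from compound 1 to compound 4 (1.55 log units; beyond the scatter). A change away from the carbonyl carbon thus also gives a large step, with the amino kept on that carbonyl carbon. Compound 1 stands at a limit, so this step has only a lower bound: the limit of < 5000 nM in this assay, at which 1 of the 4 values shown sits.

As far as these compounds go, whether a carboxylic acid or an amine at this aromatic carbon would give a similar step stays open. Also open, from the compounds shown here alone, is how methylcarbamoyl here combines with 3-hydroxypyrrolidin-1-yl on the carbonyl carbon.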